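Furan-2-yl for thiophen-3-yl on a shared pyridyl core

This account rests on a few compounds, and the source may have more. Where it says the series, first, only, none or still open, it means among the compounds named here.

The series shares one core carrying a 3-hydroxyphenyl group and a 2-chlorophenyl group, and differs only in the third aromatic substituent. Compound 1 `Oc1cccc(-c2cc(-c3cccnc3)nc(-c3ccccc3Cl)c2)c1` carries a pyridin-3-yl group there; in a functional assay on T47D cells (Homo sapiens) for cytotoxicity, read by CCK-8 assay and cell counting, with a stated time of 2 days (a higher number here means a weaker inhibitor, a lower number a stronger inhibitor), compound 1 gives "not determined" (no result reported), so no number is available for it. Compound 2 `Oc1cccc(-c2cc(-c3ccccc3)nc(-c3ccccc3Cl)c2)c1` carries a phenyl group and gives 2920 nM in this assay. Compound 3 `Oc1cccc(-c2cc(-c3ccsc3)nc(-c3ccccc3Cl)c2)c1` carries a thiophen-3-yl group and gives 2440 nM in this assay. Compound 3 therefore stands at the lowest of the two numbers, but the step of a 1.2-fold lower number from compound 2 to compound 3 (0.08 log units; within the scatter) shows that this lies within the scatter, so the two compounds cannot be told apart on these data.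

Compound 4 `Oc1cccc(-c2cc(-c3ccco3)nc(-c3ccccc3Cl)c2)c1` is not yet measured. The change furan-2-yl in place of thiophen-3-yl on an aromatic carbon exchanges one five-membered aromatic ring with one hetero atom for another of the same size and count. Going by the values given here, the only measured step that bears on this position, a 1.2-fold lower number from compound 2 to compound 3 (0.08 log units; within the scatter), was within the scatter. No step beyond the scatter is therefore expected in this assay for the move from thiophen-3-yl to furan-2-yl; the expected step is a 1.1-fold higher number from compound 3 to compound 4 (0.04 log units; within the scatter). Compound 4 is thus estimated to give 2700 nM in this assay, with a range from 1200 nM to 6000 nM.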

Compound 4, half-maximal inhibitory concentration: 2010 nM
For compound 4 the middle estimate is 1.3-fold (0.13 log units) above the measured one; the measured number falls inside the stated range.
By their numbers in this assay, from the lowest: compounds 4, 3 and 2 (each within the scatter of the next).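

In this assay, furan-2-yl in place of thiophen-3-yl gives a 1.2-fold lower number from compound 3 to compound 4 (0.08 log units; within the scatter), and furan-2-yl in place of phenyl gives a 1.5-fold lower number from compound 2 to compound 4 (0.16 log units; within the scatter). This position, next to the ring nitrogen, has now carried phenyl, thiophen-3-yl and furan-2-yl, and neither the exchange of sulfur-containing for oxygen-containing five-membered ring nor the wider exchange from phenyl separates the compounds beyond the scatter, so the three cannot be ranked on these data. No measurement is available that would explain this lack of separation.

Going by these compounds, the three compounds with numbers all carry an aromatic ring at this position, and compound 1, with pyridin-3-yl, gives "not determined" (no result reported), so it remains open whether a ring containing nitrogen, an amine, a carboxylic acid or a longer alkyl chain there would give a step beyond the scatter. Also open is how the numbers respond to changes elsewhere, as the 3-hydroxyphenyl and 2-chlorophenyl groups are the same in every compound shown, and replacing the hydroxyl with a methoxy group or the chlorine with a fluorine remains untested in this account.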